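The source may report more compounds than this note shows. Statements on the series, on what has been measured and on what is new or still open speak of the compounds shown alone.

The compounds share one core bearing an oxygen on an aromatic ring, and differ only in what sits on the saturated chain carbon bound to that oxygen. Compound 1 `C=CCOc1ccc2c(=O)c(-c3cc(OC)c(OC)cc3OC)coc2c1` carries a vinyl there, compound 2 `COc1cc(OC)c(-c2coc3cc(OCc4ccccc4)ccc3c2=O)cc1OC` a phenyl, and compound 3 `COc1cc(OC)c(-c2coc3cc(OCC(=O)c4cccc(C(F)(F)F)c4)ccc3c2=O)cc1OC` a (3-(trifluoromethyl)phenyl)carbonyl. In a functional assay on B16 cells (Mus musculus) for antiproliferative activity, read by MTT assay, with a stated time of 24 h (a higher number here means a weaker inhibitor, a lower number a stronger inhibitor), compound 1 gives 5100 nM. In this assay compound 2 gives 2330 nM, the lowest of the two numbers obtained. For compound 3 this assay reports only a limit, > 10000 nM (the limit of > 10000 nM in this assay, at which 1 of the 3 values shown sits). Accordingly a 2.2-fold lower number from compound 1 to compound 2 (0.34 log units; beyond the scatter), whereas an at least 4.2-fold higher number from compound 2 to compound 3 (0.63 log units; beyond the scatter). Compound 4 `COc1cc(OC)c(-c2coc3cc(OCc4cccc(F)c4)ccc3c2=O)cc1OC` has not yet been measured; it differs from compound 2 by fluoro in place of hydrogen on an aromatic carbon, placed on an aromatic carbon of a six-membered aromatic ring of carbon only, meta to a large group. Neither measured step tests such a change: both replace the whole group on the chain carbon rather than alter the phenyl ring itself. The step of a 1.1-fold lower number from compound 2 to compound 4 (0.02 log units; within the scatter) is therefore expected to stay within the scatter. Compound 4 is estimated at 2200 nM, between 800 nM and 6500 nM.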

Compound 4, half-maximal inhibitory concentration: 2440 nM
Compound 4: the middle estimate sits 1.1-fold (0.04 log units) below what was measured; the measured number falls inside the stated range.
By their numbers in this assay, from the lowest: compounds 2 and 4 (each within the scatter of the next); then compound 1. At a limit, above all of these: compound 3.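

Fluoro in place of hydrogen on an aromatic carbon, meta to a large group, is the first change here to the phenyl ring itself, and in this assay it gives a 1.0-fold higher number from compound 2 to compound 4 (0.02 log units; within the scatter), so the ring accepts this atom at this place without a shift beyond the scatter. Replacing the vinyl with 3-fluorophenyl gives a 2.1-fold lower number from compound 1 to compound 4 (0.32 log units; beyond the scatter), so the ring keeps its edge over the vinyl with the fluoro in place. Replacing the (3-(trifluoromethyl)phenyl)carbonyl with 3-fluorophenyl gives an at least 4.0-fold lower number from compound 3 to compound 4 (0.61 log units; beyond the scatter), a step that rests on a limit and not on a number: the limit of > 10000 nM in this assay, at which 1 of the 4 values shown sits.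

Going by these compounds, whether a methoxy, a nitrile or an amine at this ring place would leave the number just as unmoved remains open. So does whether the carbonyl or the trifluoromethyl accounts for the limit of compound 3.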